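The source may hold more compounds than are shown below. What is called first, only, known or untested is meant among the compounds shown, and "the series" means these compounds.

Among the compounds with values here, compound 3 `CC(C)(C)OC(=O)NC(=O)c1ccc(CN2C(=O)c3ccccc3S2(=O)=O)cc1` gives the highest of the three numbers so far: in a functional assay on RAW264.7 cells (Mus musculus) for inhibition (a lower number here means a stronger inhibitor, a higher number a weaker inhibitor), compound 3 gives 64700 nM. Its two neighbours sit not far away. Compound 1 `O=C(NCc1ccco1)c1ccc(CN2C(=O)c3ccccc3S2(=O)=O)cc1` gives 24300 nM in this assay, and compound 2 `CC(C)(C)OC(=O)N(C(=O)OC(C)(C)C)C(=O)c1ccc(CN2C(=O)c3ccccc3S2(=O)=O)cc1` gives 33400 nM. The step of a 2.7-fold higher number from compound 1 to compound 3 (0.43 log units; beyond the scatter) carries a modest rise, whereas the step of a 1.9-fold higher number from compound 2 to compound 3 (0.29 log units; within the scatter) stays within the scatter.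

Compound 4 `CC(C)(C)OC(=O)N(Cc1ccco1)C(=O)c1ccc(CN2C(=O)c3ccccc3S2(=O)=O)cc1` differs from compound 3 in one place: (furan-2-yl)methyl in place of hydrogen on an amide-type nitrogen. Within the data shown here, two measured steps bear on this. The step from compound 1 to compound 3, read in reverse, suggests that putting the (furan-2-yl)methyl group back on the amide-type nitrogen lowers the number somewhat, and the step from compound 2 to compound 3 shows that filling the free position on that nitrogen with a second group hardly moves it. Compound 4 is therefore expected to come out a little below compound 3, by about a 2.5-fold lower number from compound 3 to compound 4 (0.40 log units; beyond the scatter), a shift near the edge of the scatter. The estimate for compound 4 in this assay is 26000 nM, with a range from 9000 nM to 75000 nM.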

Compound 4, half-maximal inhibitory concentration: 2610 nM
Estimate against measurement, compound 4: 10-fold (1.00 log units) above, outside the stated range (below it).
By their numbers in this assay, from the lowest: compound 4; then compounds 1, 2 and 3 (each within the scatter of the next, the first and the last beyond it).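

With both (furan-2-yl)methyl and tert-butoxycarbonyl on the amide-type nitrogen, compound 4 is the strongest inhibitor of the four in this assay, as shown by a 25-fold lower number from compound 3 to compound 4 (1.39 log units; beyond the scatter), a 13-fold lower number from compound 2 to compound 4 (1.11 log units; beyond the scatter) and a 9.3-fold lower number from compound 1 to compound 4 (0.97 log units; beyond the scatter). The effect of a group at this position therefore depends on what else sits on that nitrogen, as seen when tert-butoxycarbonyl replaces (furan-2-yl)methyl: the same change on two cores in this assay, a 2.7-fold higher number (0.43 log units; beyond the scatter) from compound 1 to compound 3 and a 13-fold higher number (1.11 log units; beyond the scatter) from compound 4 to compound 2, 4.8-fold (0.68 log units) apart, beyond the scatter of two such steps. The same holds when hydrogen replaces tert-butoxycarbonyl, a change that barely registered on the earlier pair: the same change on two cores in this assay, a 1.9-fold higher number (0.29 log units; within the scatter) from compound 2 to compound 3 and a 9.3-fold higher number (0.97 log units; beyond the scatter) from compound 4 to compound 1, 4.8-fold (0.68 log units) apart, beyond the scatter of two such steps.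

The compounds shown leave open whether a benzyl group in place of the (furan-2-yl)methyl, or an acetyl or methoxycarbonyl group in place of the tert-butoxycarbonyl, would keep the low number of compound 4. They also cannot tell why the two groups together outdo either one alone.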